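Hexynyl chain on the fused core: expected cytotoxicity

This account rests on a few compounds, and the source may have more. Where it says the series, first, only, none or still open, it means among the compounds named here.

Compound 1 `CCCCCCCC#Cc1cc2cn(COCCO)c(=O)nc2o1` gives 200000 nM in a functional assay on HEL cells (Homo sapiens), read by microscopy; on this read-out lower numbers stand for higher toxicity in this test and higher numbers for lower toxicity in this test. Compound 2 `CCCCCCCc1cc2cn(COCCO)c(=O)nc2o1` gives 400000 nM in this assay. Compound 3 `O=c1nc2occc2cn1COCCO` gives > 400000 nM in this assay.

Compound 3 stands at a limit rather than a number, namely (the limit of > 400000 nM in this assay, at which 1 of the 3 values shown sits). Compound 4 `CCCCC#Cc1cc2cn(COCCO)c(=O)nc2o1` is not yet measured; it differs from compound 3 by hex-1-yn-1-yl in place of hydrogen on an aromatic carbon. For the measured compounds named here, the one measured step at this position is a number no lower from compound 2 to compound 3 (the limit leaves the size open), which runs the other way and whose size stays open. Compound 1 and compound 2 both carry a chain there and both give numbers rather than a limit. Compound 4 is therefore expected to fall to lower numbers, a step estimated as an at least 1.3-fold lower number from compound 3 to compound 4 (0.12 log units; that floor lies within the scatter). The value of compound 4 in this assay is estimated at 300000 nM, within 150000 nM to 600000 nM.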

Compound 4, minimum cytotoxic concentration: > 100000 nM
Compound 4: no number, only a limit; the forecaster's own chance of this, stated with the estimate: 25%; the middle value lies beyond the limit too.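

For the compounds shown here, no step from compound 1, compound 2 or compound 3 to compound 4 can be read in this assay, where compound 4 stands at a limit: the limit of > 100000 nM in this assay, at which 1 of the 4 values shown sits.

The compounds shown leave open whether compound 4, with its hex-1-yn-1-yl chain, differs from compound 3 at all, and in which direction.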